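Isopropyl to tert-butyl on a carbonate-like ester chain

The source may hold more compounds than are shown below. What is called first, only, known or untested is meant among the compounds shown, and "the series" means these compounds.

The study looks at metabolic stability in an ADME assay on a cell-free system (plasma, Rattus norvegicus) for metabolic stability, read by LC-MS, with a stated time of 60 min, at 37 degrees C, tested at 50 uM; a higher number here means that more of the compound is left, a lower number that less of the compound is left. Three compounds carry the same core: compound 1 `CC(C)OC(=O)c1cccc(NC(=O)[C@@H]2C[C@H](SC3=C(C(=O)O)N4C(=O)[C@H]([C@@H](C)O)[C@H]4[C@H]3C)CN2)c1`, compound 2 `CCOC(=O)c1cccc(NC(=O)[C@@H]2C[C@H](SC3=C(C(=O)O)N4C(=O)[C@H]([C@@H](C)O)[C@H]4[C@H]3C)CN2)c1` and compound 3 `CC(C)C(=O)OCOC(=O)c1cccc(NC(=O)[C@@H]2C[C@H](SC3=C(C(=O)O)N4C(=O)[C@H]([C@@H](C)O)[C@H]4[C@H]3C)CN2)c1`. For compound 1 this assay gives "not determined" (no result reported), and for compound 2 it gives "not determined" (no result reported), so neither contributes a number. Compound 3 is the only one with a result: in this assay compound 3 gives 0%, the lowest possible reading, with nothing of the compound left after the stated time. Compound 4 `C[C@@H](O)[C@H]1C(=O)N2C(C(=O)O)=C(S[C@@H]3CN[C@H](C(=O)Nc4cccc(C(=O)OCOC(=O)C(C)(C)C)c4)C3)[C@H](C)[C@H]12` is the next compound to be measured. It differs from compound 3 in a single change: methyl in place of hydrogen on a saturated chain carbon bound to a carbonyl carbon and two saturated chain carbons. Among the measured compounds shown here, no pair of measured compounds shows a step in this assay, so the size of this change can only be estimated. Compound 3 gives 0% in this assay. A small rise is expected, described by the step of a number 10 percentage points higher from compound 3 to compound 4 (within the scatter). For compound 4 the expected result in this assay is 10%, within a range from 0% to 40%.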

Compound 4, percent of the compound remaining in the plasma assay: 0%
Beside the measured number, compound 4's estimate is 10 percentage points above it; low and high end bracket the measured number.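

Among the compounds shown here, in the plasma assay, where the earlier compounds offered no step, isopropyl to tert-butyl on the ester chain now gives a reading for this position: no change at the digits printed from compound 3 to compound 4 (within the scatter), so the added methyl on a saturated chain carbon bound to a carbonyl carbon and two saturated chain carbons leaves the reading at the bottom of the scale. In a physicochemical assay for metabolic stability, read by LC-MS, in phosphate buffer, with a stated time of 3 h, at pH 7.4, tested at 50 uM (a lower number here means that less of the compound is left, a higher number that more of the compound is left), compound 3 gives > 95%, which is a limit of the assay. In the physicochemical assay compound 4 gives > 95%, which is likewise a limit of the assay.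

On these data alone, the step between these two compounds in the physicochemical assay cannot be read, because both values sit at the same limit: the limit of > 95% in the physicochemical assay, at which 2 of the 2 values shown sit. Still open is whether an amine or a longer chain in place of the tert-butyl would leave any compound in the plasma assay.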